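The compounds below may be only part of what the source reports. "The series", "measured", "known", "first", "only" and "open" are said of these compounds alone.

Measured so far in an assay for inhibition of mitogen-activated protein kinase kinase kinase 14 (Homo sapiens), read by luminescence and ADP-Glo, with a stated time of 120 min, in the presence of a further agent that is not named here; on this read-out lower numbers stand for stronger inhibition and higher numbers for weaker inhibition:
Compound 1 `CN(C)c1ccc(C#CC(C)(O)c2nccs2)cc1Nc1ncnc2[nH]ccc12` gives 22.5 nM.
Compound 2 `C[C@H]1CN(c2ccc(C#CC(C)(O)c3nccs3)cc2Nc2ncnc3[nH]ccc23)CCN1` gives 69.2 nM.
Compound 3 `CC(O)(C#Cc1ccc(N2CC3CC2CN3)c(Nc2ncnc3[nH]ccc23)c1)c1nccs1` gives 200 nM.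

Compound 3 stands highest of the three, that is, it is the weakest inhibitor shown; the gaps to it are a 2.9-fold higher number from compound 2 to compound 3 (0.46 log units; beyond the scatter) and an 8.9-fold higher number from compound 1 to compound 3 (0.95 log units; beyond the scatter). Compound 4 `CC(O)(C#Cc1ccc(OC2CCOCC2)c(Nc2ncnc3[nH]ccc23)c1)c1nccs1` carries a group of 7 heavy atoms (5 carbon, 2 oxygen; one six-membered non-aromatic ring with 1 hetero atom) in place of a group of 7 heavy atoms (5 carbon, 2 nitrogen; 2 five-membered non-aromatic rings with 1 hetero atom each), on an aromatic carbon. Among the measured compounds shown here, all three measured steps change the group at this same aromatic carbon, and all were modest, so a shift of similar size is plausible here; no measured compound has an oxygen-linked group at that carbon, so the direction is uncertain. Since the smaller group in compound 1 gave 22.5 nM and the larger ones weaker numbers, the expected step is a 2.0-fold lower number from compound 3 to compound 4 (0.30 log units; within the scatter), a modest improvement. Compound 4 is thus estimated at 100 nM, within 30 nM to 350 nM.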

Compound 4, half-maximal inhibitory concentration: 112 nM
Compound 4: middle estimate off by 1.1-fold (0.05 log units), on the low side; the measured number falls inside the stated range.
By their numbers in this assay, from the lowest: compound 1; then compounds 2, 4 and 3 (each within the scatter of the next, the first and the last beyond it).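

At this aromatic carbon, (oxan-4-yl)oxy brings the first oxygen link, and in this assay it sits level with the larger nitrogen-linked rings, with a 1.8-fold lower number from compound 3 to compound 4 (0.25 log units; within the scatter) and a 1.6-fold higher number from compound 2 to compound 4 (0.21 log units; within the scatter). The hydrogen-bond donor counted in the group leaving compound 3 is absent from the group in compound 4, yet that step stays within the scatter. The small dimethylamino group remains clearly ahead, with a 5.0-fold higher number from compound 1 to compound 4 (0.70 log units; beyond the scatter).

Nothing available explains these numbers. From the compounds shown here alone, whether a small oxygen-linked group such as methoxy would match dimethylamino remains open.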